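Changing the aryl group on the shared core of compound 2

The source may hold more compounds than are shown below. What is called first, only, known or untested is meant among the compounds shown, and "the series" means these compounds.

Three compounds with a common core have been examined in an assay (Rattus norvegicus) for inhibition of Fatty-acid amide hydrolase 1 (Homo sapiens); a higher number here means a weaker inhibitor, a lower number a stronger inhibitor. Compound 1, `NS(=O)(=O)c1ccccc1-c1cnc(C(=O)CCCCCCc2ccccc2)o1`, gives 1500 nM. Compound 2, `O=C(CCCCCCc1ccccc1)c1ncc(-c2cccc(O)c2)o1`, gives 50 nM. Compound 3, `O=C(CCCCCCc1ccccc1)c1ncc(-c2cc(C(F)(F)F)ccn2)o1`, gives 3.5 nM. Within this set compound 2 holds the second highest number: compound 3 sits well below it and compound 1 well above it, both gaps lying beyond the usual scatter.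

Compound 4, `NC(=O)c1ccc(-c2cnc(C(=O)CCCCCCc3ccccc3)o2)nc1`, has not yet been measured in this assay. It differs from compound 2 in one place: 5-carbamoylpyridin-2-yl in place of 3-hydroxyphenyl on an aromatic carbon. The two aryl groups that have already been measured on the same position of the core point in different directions, with compound 1 the weakest and compound 3 the strongest of the three, so the unmeasured group could land anywhere in that span. Since compound 3 shows that an aromatic ring with a hetero atom in this position goes with a low number, 3.5 nM, the step of an 8.3-fold lower number from compound 2 to compound 4 (0.92 log units; beyond the scatter) is expected to be a decrease of moderate size, beyond the scatter. Compound 4 is therefore estimated at 6 nM, with a likely range from 1.5 nM to 30 nM.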

Compound 4, inhibition constant: 1.2 nM
Compound 4: middle estimate off by 5.0-fold (0.70 log units), on the high side, and the stated range ends above it.
By their numbers in this assay, from the lowest: compound 4; then compound 3; then compound 2; then compound 1.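

In this assay, replacing 3-hydroxyphenyl with 5-carbamoylpyridin-2-yl gives a 42-fold lower number from compound 2 to compound 4 (1.62 log units; beyond the scatter), so this position of the shared core can take a larger group with a carbamoyl substituent and still give a low number. The printed values also show that a ring with a hetero atom and a nitrogen-bearing substituent can sit here at a low number: compound 3 (3.5 nM) has a ring with a hetero atom but a trifluoromethyl substituent, compound 1 (1500 nM) has a sulfonamide on a ring of carbon only, and compound 4 (1.2 nM) combines a ring with a hetero atom and a carbamoyl group. No measurement shown accounts for the size of this step.

The change from compound 2 to compound 4 alters the ring and its substituent together, so the share of each in the step remains unresolved. The compounds shown include neither an unsubstituted pyridin-2-yl group nor a 3-carbamoylphenyl group, and they leave open how a carboxylic acid in place of the carbamoyl group would read in this assay.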